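Series notes: quinazoline acrylamides, halogen pattern on the aniline

The source may report more compounds than this note shows. Statements on the series, on what has been measured and on what is new or still open speak of the compounds shown alone.

Measured:
- compound 1, `CN(C)C/C=C/C(=O)Nc1cc2ncnc(Nc3ccc(F)c(Cl)c3)c2cc1O[C@@H]1CCOC1`: 9920 nM
- compound 2, `C=CC(=O)Nc1cc2c(Nc3ccc(F)c(Cl)c3)ncnc2cc1OCc1cn(CCCCC(=O)NO)nn1`: > 50000 nM

In a functional assay on NCI-H838 cells (Homo sapiens) for antiproliferative activity, read by MTT assay, with a stated time of 72 h (on this read-out higher numbers stand for weaker inhibition and lower numbers for stronger inhibition), compound 1 gives 9920 nM. Compound 2 is reported only as a limit, > 50000 nM, not as a number. Compound 2 therefore stands at the limit of > 50000 nM in this assay, at which 1 of the 2 values shown sits, the weaker end of the two values shown.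

Compound 3, `C=CC(=O)Nc1cc2c(Nc3cccc(Cl)c3F)ncnc2cc1OCc1cn(CCCCC(=O)NO)nn1`, is not yet measured. It differs from compound 2 by 3-chloro-2-fluorophenyl in place of 3-chloro-4-fluorophenyl on a nitrogen on an aromatic ring. Going by the values given here, no measured pair in this set isolates such a change, so no step size can be read from the data; the expectation is a shift of compound 3 relative to compound 2 within the scatter, in no firm direction. Compound 3 is expected at 60000 nM, between 15000 nM and 200000 nM, corresponding to an estimated step that the limit leaves unreadable from compound 2 to compound 3.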

Compound 3, half-maximal inhibitory concentration: > 50000 nM
Compound 3: only a limit was reported (the forecaster's own chance of this, stated with the estimate: 65%); the middle value is on the limit's open side.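

Going by these compounds alone, compound 3 is reported only as a limit (> 50000 nM); compound 2 is also only a limit, so no step between compound 2 and compound 3 can be read. On these data alone, whether 3-chloro-2-fluorophenyl and 3-chloro-4-fluorophenyl differ in this assay stays open.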